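The source may report more compounds than this note shows. Statements on the series, on what has been measured and on what is new or still open speak of the compounds shown alone.

Measured in a functional assay on U-87MG ATCC cells (Homo sapiens) for antiproliferative activity; a higher number here means a weaker inhibitor, a lower number a stronger inhibitor:
compound 1 `CC(=O)N1CCc2c(C)c3c(n2-c2ccc(C(N)=O)c(c2)N[C@@H](C)[C@H](C)C1)CC(C)(C)CC3=O` gives 24 nM
compound 2 `Cc1c2c(n3c1CCN(C(=O)CN)C[C@@H](C)[C@H](C)Nc1cc-3ccc1C(N)=O)CC(C)(C)CC2=O` gives 378 nM
compound 3 `CC[C@H](N)C(=O)N1CCc2c(C)c3c(n2-c2ccc(C(N)=O)c(c2)N[C@@H](C)[C@H](C)C1)CC(C)(C)CC3=O` gives 45 nM

Compound 3 sits close to compound 1 and far from compound 2 on these numbers. The two steps that place it are a 1.9-fold higher number from compound 1 to compound 3 (0.27 log units; within the scatter) and an 8.4-fold lower number from compound 2 to compound 3 (0.92 log units; beyond the scatter) on the same read-out.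

Compound 4 `Cc1c2c(n3c1CCN(C(=O)[C@@H](N)C(C)C)C[C@@H](C)[C@H](C)Nc1cc-3ccc1C(N)=O)CC(C)(C)CC2=O` carries one change relative to compound 3: methyl in place of hydrogen on a saturated chain carbon bound to two saturated chain carbons that is, methyl in place of hydrogen on a saturated chain carbon bound to two saturated chain carbons, so that 1-aminopropyl becomes 1-amino-2-methylpropyl.

Going by the values given here, the closest precedent is the ethyl step into compound 3, modest in size. The large step, a 16-fold higher number from compound 1 to compound 2 (1.20 log units; beyond the scatter) is the amino change, and compound 4 keeps that amino group. Among the compounds with values here, no measured pair tests a methyl on this carbon. In this assay no step beyond the scatter is therefore expected, and the estimate is a 1.1-fold lower number from compound 3 to compound 4 (0.05 log units; within the scatter) in size. Compound 4 is estimated at 40 nM with an expected range from 15 nM to 110 nM for the coming measurement.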

Compound 4, half-maximal inhibitory concentration: 48 nM
Compound 4: the middle estimate sits 1.2-fold (0.08 log units) below what was measured; the measured number falls inside the stated range.
By their numbers in this assay, from the lowest: compounds 1, 3 and 4 (each within the scatter of the next); then compound 2.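

In this assay, ethyl to isopropyl on the saturated chain carbon gives no readable difference (a 1.1-fold higher number from compound 3 to compound 4 (0.03 log units; within the scatter)), so this position accepts the extra methyl without a step beyond the scatter. The isopropyl group in place of hydrogen gives a step beyond the scatter (a 7.9-fold lower number from compound 2 to compound 4 (0.90 log units; beyond the scatter)), as the ethyl group does (an 8.4-fold lower number from compound 2 to compound 3 (0.92 log units; beyond the scatter)), so the difference from the unbranched aminoacetyl compound now holds for two carbon groups. Compound 4, with 1-amino-2-methylpropyl in place of methyl, also stays within the scatter of the acetyl compound (a 2.0-fold higher number from compound 1 to compound 4 (0.30 log units; within the scatter)), and nothing at hand explains these results.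

Still open, as far as these compounds go, is whether a longer chain such as butyl, or a benzyl group, on this carbon would keep the number in this range. From the compounds shown here alone, the effect of a hydroxyl group in place of the amino group on the same carbon also remains open.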